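The source may hold more compounds than are shown below. What is called first, only, known or untested is meant among the compounds shown, and "the series" means these compounds.

Of the compounds shown here, three built on a shared core have been measured in a physicochemical assay for pharmacokinetics, read by LC-MS, in phosphate buffer, at pH 7.4, in the presence of a further agent that is not named here; a lower number here means that the compound disappears faster, a higher number that the compound lasts longer. Compound 1 `C=CC(=O)N1CC(NC(=O)Cn2cc(C(=O)N3CCc4ccccc4C3)c3cc(Br)ccc32)C1` gives 1.67 h in this assay. Compound 2 `C=CC(=O)N1CC(NC(=O)Cn2c(C3CC3)c(C(=O)N3CCc4c(cccc4OC)C3)c3cc(Br)ccc32)C1` gives 1.67 h, and compound 3 `C=CC(=O)N1CC(NC(=O)Cn2c(C)c(C(=O)N3CCc4c(cccc4OC)C3)c3cc(Cl)ccc32)C1` gives 1.67 h; on these numbers compound 1 stands level with both, the three values coinciding at the digits shown and lying within the usual scatter of each other. Compound 4 `C=CC(=O)N1CC(NC(=O)Cn2cc(C(=O)N3CCc4c(Cl)cccc4C3)c3cc(Br)ccc32)C1` has not yet been measured in this assay. It differs from compound 1 in one place: chloro in place of hydrogen on an aromatic carbon. Among the measured compounds shown here, no step between measured compounds covers this change. Compound 4 is expected to show no step beyond the scatter, the expected step being no change at the digits printed from compound 1 to compound 4 (within the scatter). Compound 4 is estimated at 1.67 h, between 0.9 h and 3.1 h.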

Compound 4, half-life: 1.67 h
The estimate for compound 4 equals the measured number at the digits printed; measured number inside the range.
By their numbers in this assay, from the lowest: compounds 1, 2, 3 and 4 (each within the scatter of the next).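

In this assay chloro in place of hydrogen on an aromatic carbon brings no change at the digits printed from compound 1 to compound 4 (within the scatter) at this position, ortho to a fused ring. Among the compounds shown here, this is the first step in the set that changes one place alone, so this one change can now be read by itself, which the earlier compounds did not allow. No measured evidence bears on this result. As far as these compounds go, whether an amine or a carboxylic acid at this same position would also stay within the scatter remains open. So does whether chloro would do the same at another position on this ring.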